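The source may report more compounds than this note shows. Statements on the series, on what has been measured and on what is new or still open speak of the compounds shown alone.

Compound 2 `O=C(COc1ccc2cc(/C=C3/SC(=O)NC3=O)ccc2c1)Nc1cccc(F)n1` gives 7200 nM in an assay on isolated protein for inhibition of histone deacetylase 8 (Homo sapiens), with a stated time of 1 h; a lower number here means a stronger inhibitor, a higher number a weaker inhibitor. Among the measured compounds shown here, the only other measured compound, compound 1 `Cc1ccc(NC(=O)COc2ccc3cc(/C=C4/SC(=O)NC4=O)ccc3c2)cc1`, gives 9000 nM in this assay, and the step of a 1.3-fold lower number from compound 1 to compound 2 (0.10 log units; within the scatter) separates the two by no more than the scatter. Compound 3 `O=C(COc1ccc2cc(/C=C3/SC(=O)NC3=O)ccc2c1)Nc1ccc(F)cc1F` differs from compound 2 by 2,4-difluorophenyl in place of 6-fluoropyridin-2-yl on an amide-type nitrogen. For the measured compounds named here, the one step that bears on this, a swap of the ring on the same nitrogen, was a 1.3-fold lower number from compound 1 to compound 2 (0.10 log units; within the scatter), so no step beyond the scatter is expected here in this assay. Compound 3 is therefore estimated at 8000 nM (range 3500 nM to 18000 nM), an expected step of a 1.1-fold higher number from compound 2 to compound 3 (0.05 log units; within the scatter).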

Compound 3, half-maximal inhibitory concentration: > 50000 nM
Compound 3 ended at the assay's limit; the forecaster's own chance of this, stated with the estimate: 5%; at least 6.2-fold (0.79 log units) between middle value and limit.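

Compound 3 shows that the ring on this amide-type nitrogen matters in this assay, with an at least 6.9-fold higher number from compound 2 to compound 3 (0.84 log units; beyond the scatter) and an at least 5.5-fold higher number from compound 1 to compound 3 (0.74 log units; beyond the scatter). Compound 1 also carries a carbon-only ring, so the absence of a ring nitrogen does not by itself set compound 3 apart. Compound 3 stands at a limit of this assay, not at a number, so the full size of both steps is unknown: the limit of > 50000 nM in this assay, at which 1 of the 3 values shown sits.

As far as these compounds go, whether the loss comes from having two fluorines on the ring remains open. So does how a plain phenyl ring, or a phenyl ring carrying a single fluorine or an amine, would behave.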